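Replacing Neopentyl by Oxolan-3-yl on the Amide

The source may hold more compounds than are shown below. What is called first, only, known or untested is meant among the compounds shown, and "the series" means these compounds.

Measured so far:
compound 1 `Cc1cc(C(=O)NCc2ccncc2)nn1Cc1cc(Cl)ccc1OCc1ccccc1`: 79.4 nM
compound 2 `Cc1cc(NC(=O)CC(C)(C)C)nn1Cc1cc(Cl)ccc1OCc1ccccc1`: 10 nM

In an assay on CHO-K1 cells for displacement of a labelled ligand from prostaglandin E2 receptor EP1 subtype (Homo sapiens) (on this read-out lower numbers stand for stronger inhibition and higher numbers for weaker inhibition), compound 2 gives 10 nM, the lowest of the two numbers; compound 1 gives 79.4 nM. Within the data shown here, the single measured step, a 7.9-fold lower number from compound 1 to compound 2 (0.90 log units; beyond the scatter), lies beyond the scatter but rewrites the whole side group, not the acyl part of the amide.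

Compound 3 `Cc1cc(NC(=O)C2CCOC2)nn1Cc1cc(Cl)ccc1OCc1ccccc1` differs from compound 2 in one place: oxolan-3-yl in place of neopentyl on a carbonyl carbon. Among the measured compounds shown here, no measured step touches this acyl group, so there is no direct guide for its size or direction. A change from a branched chain to a small ring carrying one acceptor is, on this series, untested. Compound 3 is therefore expected to give 25 nM in this assay, with a range from 7 nM to 100 nM, which corresponds to an expected step of a 2.5-fold higher number from compound 2 to compound 3 (0.40 log units; beyond the scatter), wide because the evidence is thin.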

Compound 3, half-maximal inhibitory concentration: 39.8 nM
Beside the measured number, compound 3's estimate is 1.6-fold (0.20 log units) below it, within the range that was stated.
By their numbers in this assay, from the lowest: compound 2; then compounds 3 and 1 (each within the scatter of the next).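

In this assay, the acyl group on the amide proves to be a position that responds: oxolan-3-yl in place of neopentyl on a carbonyl carbon, with both groups holding 5 heavy atoms, gives a 4.0-fold higher number from compound 2 to compound 3 (0.60 log units; beyond the scatter) and so brings in a ring and a hydrogen-bond acceptor at a measurable cost. The gain seen with compound 2 does not carry over to every amide of this type, since a 2.0-fold lower number from compound 1 to compound 3 (0.30 log units; within the scatter) leaves compound 1 and compound 3 indistinguishable on this read-out. No measured evidence explains the step from neopentyl to oxolan-3-yl.

The compounds shown leave open whether the ring itself or its oxygen goes with this step, a question that a cyclopentyl group on the same carbonyl carbon would separate. Also open, from the compounds shown here alone, is how a tert-butyl group or a longer chain such as n-hexyl would read at this position.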